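Third methoxy on the benzylamine of the shared core

The source may hold more compounds than are shown below. What is called first, only, known or untested is meant among the compounds shown, and "the series" means these compounds.

Measured so far:
compound 1 `Nc1cc(N)c2nc(-c3ccccc3)c(NCc3ccc(Cl)c(Cl)c3)nc2c1` — 15800 nM
compound 2 `COc1ccc(CNc2nc3cc(N)cc(N)c3nc2-c2ccccc2)cc1OC` — 4270 nM
compound 3 `CCOC(=O)[C@H](CCC(=O)O)NC(=O)c1ccc(Sc2nc3cc(N)cc(N)c3nc2-c2ccccc2)cc1` — 33100 nM

All three were run in a functional assay on M14 cells (Homo sapiens) for inhibition, read by sulforhodamine B assay, with a stated time of 48 h; on this read-out lower numbers stand for stronger inhibition of growth and higher numbers for weaker inhibition of growth. Compound 2 gives the lowest number of the three; compound 1 sits nearer, compound 3 further away, both steps beyond the scatter. For the measured compounds named here, the only single-point step available is a 3.7-fold lower number from compound 1 to compound 2 (0.57 log units; beyond the scatter), a swap on the benzylic carbon bound to the ring nitrogen.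

Compound 4 `COc1cc(CNc2nc3cc(N)cc(N)c3nc2-c2ccccc2)cc(OC)c1OC` differs from compound 2 by methoxy in place of hydrogen on an aromatic carbon. Going by the values given here, no measured pair isolates the addition of a third methoxy, so the step from compound 1 to compound 2 bears only indirectly. A small change, likely within the scatter, is expected for compound 4, a 1.2-fold lower number from compound 2 to compound 4 (0.09 log units; within the scatter). The estimate for compound 4 is 3500 nM, with a range of 1500 nM to 10000 nM.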

Compound 4, concentration for 50% growth inhibition: 9550 nM
Compound 4: the middle estimate sits 2.7-fold (0.44 log units) below what was measured; low and high end bracket the measured number.
By their numbers in this assay, from the lowest: compound 2; then compounds 4 and 1 (each within the scatter of the next); then compound 3.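

Methoxy in place of hydrogen on an aromatic carbon, ortho to a methoxy group, gives a 2.2-fold higher number from compound 2 to compound 4 (0.35 log units; beyond the scatter) and so is not a neutral change at this position. The step from compound 1 to compound 2 therefore does not continue with a third methoxy, and compound 2 keeps the lowest number of the compounds shown. Nothing measured here explains the shift.

Still open, going by these compounds, is whether a hydroxy group or an amine on this same aromatic carbon would follow methoxy. A single methoxy on the benzylamine is also untested among the compounds shown.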